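The source may report more compounds than this note shows. Statements on the series, on what has been measured and on what is new or still open speak of the compounds shown alone.

Measured so far:
compound 1 `Cc1cccc(Oc2ccc(C#N)cc2S(=O)(=O)NC(=O)NC(C)C)c1` with 1690 nM
compound 2 `CC(C)NC(=O)NS(=O)(=O)c1cc(C#N)ccc1Oc1ccc(F)cc1` with 9300 nM

Compound 2 stands at the highest of the two numbers recorded in a functional assay on HEK293 cells for antagonist activity at thromboxane A2 receptor (Homo sapiens), read by fluorescence and calcium flux; a lower number here means a stronger inhibitor, a higher number a weaker inhibitor. Its nearest neighbour is compound 1, which in this assay gives 1690 nM. Within the data shown here, the one measured step between them, a 5.5-fold higher number from compound 1 to compound 2 (0.74 log units; beyond the scatter), comes from exchanging the aryl group on the ether oxygen, and compound 2 sits at the weaker end of that step.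

Compound 3 `CC(C)NC(=O)NS(=O)(=O)c1cc(C#N)ccc1Oc1ccc(Cl)cc1` is the unmeasured follow-up. It differs from compound 2 in a single place: chloro in place of fluoro on an aromatic carbon. Among the measured compounds shown here, no measured step touches a halogen swap of this kind; the only step available, from compound 1 to compound 2, exchanged a whole aryl pattern and is only loosely related to the present change. With nothing closer to lean on, the expectation is a change of at most modest size in this assay, with a slight lean towards a lower number, so that the step from compound 2 to compound 3 is estimated as a 1.9-fold lower number from compound 2 to compound 3 (0.27 log units; within the scatter). Compound 3 is therefore expected to give about 5000 nM in this assay, within a range of 1500 nM to 15000 nM.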

Compound 3, half-maximal inhibitory concentration: 8490 nM
Estimate against measurement, compound 3: 1.7-fold (0.23 log units) below; low and high end bracket the measured number.
By their numbers in this assay, from the lowest: compound 1; then compounds 3 and 2 (each within the scatter of the next).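

In this assay, chloro in place of fluoro on an aromatic carbon para to a large group gives a 1.1-fold lower number from compound 2 to compound 3 (0.04 log units; within the scatter), so this position does not distinguish the two halogens in this pair. The comparison with the 3-methylphenyl compound also holds for both halogens: 4-chlorophenyl gives a 5.0-fold higher number from compound 1 to compound 3 (0.70 log units; beyond the scatter), and 4-fluorophenyl gives a 5.5-fold higher number from compound 1 to compound 2 (0.74 log units; beyond the scatter), so the gap seen earlier is not confined to the fluoro compound. Nothing available explains why the two halogens read alike or why both compounds lie apart from compound 1.

The compounds shown leave open whether the gap to compound 1 follows from the identity of the group on the aryl ring or from its place, as each step changes both at once; a 4-methylphenyl group on the same oxygen would separate the two. They also leave open whether the flat reading extends beyond fluoro and chloro to other groups on the same carbon, such as bromo, methoxy or a carboxylic acid.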